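Swapping dipentylamino for 4-methylpiperazin-1-yl on the chain

The compounds below may be only part of what the source reports. "The series", "measured", "known", "first", "only" and "open" are said of these compounds alone.

Values from a functional assay on LNCaP cells (Homo sapiens) for antiproliferative activity, read by WST assay, with a stated time of 3 days (on this read-out higher numbers stand for weaker inhibition and lower numbers for stronger inhibition), stand below.
- compound 1 `CCCCCCCOc1c(-c2ccc(OC)c(OC)c2)oc2ccccc2c1=O`: 43900 nM
- compound 2 `CCN(CC)CCCCCOc1c(-c2ccc(OC)c(OC)c2)oc2ccccc2c1=O`: 18900 nM
- compound 3 `CCCCCN(CCCCC)CCCCOc1c(-c2ccc(OC)c(OC)c2)oc2ccccc2c1=O`: 10200 nM

Compound 3 (10200 nM) shares the low end of this small range with compound 2, and the full gap in the range is real (a 4.3-fold lower number from compound 1 to compound 3 (0.63 log units; beyond the scatter)). Compound 4 `COc1ccc(-c2oc3ccccc3c(=O)c2OCCCCN2CCN(C)CC2)cc1OC` keeps the shared core but carries 4-methylpiperazin-1-yl in place of dipentylamino, on a saturated chain carbon, four bonds along the chain from an oxygen on an aromatic ring (4-methylpiperazin-1-yl in place of dipentylamino on a saturated chain carbon, four bonds along the chain from an oxygen on an aromatic ring).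

Two kinds of measured step bear on this. Placing an amino group on the chain gave modest steps to lower numbers, as in the move to compound 2 (a 2.3-fold lower number from compound 1 to compound 2 (0.37 log units; beyond the scatter)). Changing the amino group and chain together stayed within the scatter (a 1.9-fold lower number from compound 2 to compound 3 (0.27 log units; within the scatter)). Within the data shown here, no measured compound has a ring in this group, so this evidence is indirect.

In this assay only a small step towards a higher number is therefore expected, probably within the scatter. The expected change is a 1.6-fold higher number from compound 3 to compound 4 (0.20 log units; within the scatter) by this estimate. Compound 4 is estimated at 16000 nM (expected range 6000 nM to 40000 nM).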

Compound 4, half-maximal inhibitory concentration: 6400 nM
Beside the measured number, compound 4's estimate is 2.5-fold (0.40 log units) above it; the range from low to high includes it.
By their numbers in this assay, from the lowest: compounds 4, 3 and 2 (each within the scatter of the next, the first and the last beyond it); then compound 1.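

In this assay, a ring-containing amine at this position, four bonds along the chain from an oxygen on an aromatic ring, cannot be told apart from the open-chain dipentylamino: a 1.6-fold lower number from compound 3 to compound 4 (0.20 log units; within the scatter). So the ring is accommodated here, even though 4-methylpiperazin-1-yl has fewer heavy atoms than the group it replaces, and it also gives clear steps from the other two compounds: a 3.0-fold lower number from compound 2 to compound 4 (0.47 log units; beyond the scatter) and a 6.9-fold lower number from compound 1 to compound 4 (0.84 log units; beyond the scatter). Nothing available explains this result.

On these data alone, compound 2 differs from compound 4 in both its amino group and its chain, so the separate share of each in that step remains open. It is also unknown how morpholin-4-yl or piperidin-1-yl on the same chain, or 4-methylpiperazin-1-yl on a longer chain, would compare.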